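Isopropyl to Anilinomethyl on a Shared Core

The source may hold more compounds than are shown below. What is called first, only, known or untested is meant among the compounds shown, and "the series" means these compounds.

Compound 1, `Cc1nc(Nc2ccccc2)c2cnn(-c3ccccc3)c2n1`, is the parent of this small set, and compound 2, `CC(C)c1nc(Nc2ccccc2)c2cnn(-c3ccccc3)c2n1`, differs from it by isopropyl in place of methyl on an aromatic carbon. In a functional assay on G-361 cells (Homo sapiens) for cytotoxicity, read by sulforhodamine B assay (a lower number here means a stronger inhibitor of growth, a higher number a weaker inhibitor of growth), compound 1 reaches only the limit of the assay, > 100000 nM. In this assay compound 2 likewise gives a limit, > 100000 nM. The step that the two limits leave unreadable from compound 1 to compound 2 therefore cannot be read in size or direction, because of the limit of > 100000 nM in this assay, at which 2 of the 2 values shown sit. Compound 2 thus stands at the top of the measured range, with no number to place it more precisely. Compound 3, `c1ccc(NCc2nc(Nc3ccccc3)c3cnn(-c4ccccc4)c3n2)cc1`, carries the change (anilinomethyl in place of isopropyl on an aromatic carbon). Going by the values given here, the only measured step that bears on this position is the one from methyl to isopropyl, and it was unreadable, so nothing in the data points to a particular size or direction for the effect of anilinomethyl. Compound 3 is therefore expected to remain near the limit, with a step of an at least 1.2-fold lower number from compound 2 to compound 3 (0.09 log units; that floor lies within the scatter) meaning essentially no change beyond the scatter. The estimate for compound 3 is 80000 nM, spanning 15000 nM to 300000 nM.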

Compound 3, concentration for total growth inhibition: > 100000 nM
Compound 3 gave a limit, no number; the forecaster's own chance of this, stated with the estimate: 65%; middle value at least 1.2-fold (0.09 log units) away from the limit.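

In this assay compound 3 gives > 100000 nM, which is a limit and not a number. No new step can be read, since the steps to compound 3 from compound 1 and compound 2 cannot be sized: the limit of > 100000 nM in this assay, at which 3 of the 3 values shown sit.

The compounds shown leave open how methyl, isopropyl and anilinomethyl rank against one another on the shared core.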